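Swapping the aryl group on the core of compound 1

This account rests on a few compounds, and the source may have more. Where it says the series, first, only, none or still open, it means among the compounds named here.

Among the measured compounds shown here, compound 1 `C=CCn1c(=O)/c(=C\c2cccc(Cl)c2Cl)[nH]c(=O)/c1=C\c1ccccc1OC` was tested in a functional assay on Huh-7 cells (Homo sapiens) for cytotoxicity, read by CCK-8 assay, with a stated time of 72 h (a lower number here means a stronger inhibitor, a higher number a weaker inhibitor), where compound 1 gives 1200 nM, the highest number among the two compounds measured so far. Its nearest neighbour is compound 2 `COc1ccccc1/C=c1\c(=O)[nH]/c(=C/c2cccc(Cl)c2Cl)c(=O)n1C`, which in this assay gives 300 nM. For the measured compounds named here, the only measured step, a 4.0-fold lower number from compound 1 to compound 2 (0.60 log units; beyond the scatter), concerns hydrogen in place of vinyl on a saturated chain carbon bound to an aromatic nitrogen.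

Compound 3 `C=CCn1c(=O)/c(=C\c2cc(F)ccc2C)[nH]c(=O)/c1=C\c1ccccc1OC` has not yet been measured. It differs from compound 1 at another place: 5-fluoro-2-methylphenyl in place of 2,3-dichlorophenyl on a double-bonded chain carbon bound to an aromatic carbon. The aryl group that leaves, 2,3-dichlorophenyl, and the one that enters, 5-fluoro-2-methylphenyl, both count eight heavy atoms and carry one six-membered aromatic ring of carbon only, without donors or acceptors. Going by the values given here, no measured step touches this part of the core, so the step from compound 1 to compound 2 gives no guidance here, and the expected change is none beyond the scatter, with wide uncertainty in either direction. On that basis compound 3 is estimated at 1500 nM, with a range from 400 nM to 6000 nM, meaning an expected step of a 1.3-fold higher number from compound 1 to compound 3 (0.10 log units; within the scatter).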

Compound 3, half-maximal inhibitory concentration: 5600 nM
Estimate against measurement, compound 3: 3.7-fold (0.57 log units) below; measured number inside the range.
By their numbers in this assay, from the lowest: compound 2; then compound 1; then compound 3.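

In this assay the aryl group on the double-bonded chain carbon bound to an aromatic carbon proves not to be freely interchangeable: 5-fluoro-2-methylphenyl in place of 2,3-dichlorophenyl gives a 4.7-fold higher number from compound 1 to compound 3 (0.67 log units; beyond the scatter) even though the two groups match in heavy atom count, in their single six-membered aromatic ring of carbon only and in having no hydrogen-bond donors or acceptors. Those shared counts therefore do not fix the number at this place, which now joins the saturated chain carbon bound to an aromatic nitrogen, the site of a 4.0-fold lower number from compound 1 to compound 2 (0.60 log units; beyond the scatter) as a second place where a change moves the result beyond the scatter. Nothing available here accounts for the difference between the two aryl groups.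

The change replaces both chlorines and adds fluorine and methyl in one step, leaving open which of these matters, and whether a simple unsubstituted phenyl or an aryl group carrying an amine or a carboxylic acid would fall closer to compound 1 or to compound 3. On these data alone, it also remains open whether 5-fluoro-2-methylphenyl would have a similar effect with the hydrogen-for-vinyl change of compound 2 in place.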